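Removing the allyl group from the aromatic nitrogen

This account rests on a few compounds, and the source may have more. Where it says the series, first, only, none or still open, it means among the compounds named here.

Measured compounds:
compound 1 `Cc1cccc(Cn2cc(C(=N)S)c3c(N)ncnc32)c1`: 30000 nM
compound 2 `C=CCn1cc(C(N)=S)c2c(N)ncnc21`: 19000 nM
compound 3 `NC(=S)c1cn(Cc2ccccc2)c2ncnc(N)c12`: 32000 nM

Three compounds share a core and differ only in the group on the aromatic nitrogen of the five-membered ring. In a functional assay on KB cells (Homo sapiens) for cytotoxicity (a higher number here means a weaker inhibitor, a lower number a stronger inhibitor), compound 2 gives 19000 nM, the lowest of the three numbers, yet its gaps to compound 1 and to compound 3 both lie within the scatter, so the three cannot be ordered. Among the measured compounds shown here, the one directly measured step, a 1.7-fold higher number from compound 2 to compound 3 (0.23 log units; within the scatter), shows that exchanging one group for another at that position leaves the number essentially unchanged.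

Compound 4 `NC(=S)c1c[nH]c2ncnc(N)c12` carries no group there at all: hydrogen in place of allyl on an aromatic nitrogen. For the measured compounds named here, no measured step removes the group entirely, so the comparison to compound 3 bears on it only loosely. Given that all three groups produced similar numbers, compound 4 is expected to stay near them, with the step of a 2.1-fold higher number from compound 2 to compound 4 (0.32 log units; beyond the scatter) possibly drifting toward a higher number. The estimate for compound 4 in this assay is 40000 nM, within 12000 nM to 130000 nM.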

Compound 4, half-maximal inhibitory concentration: 25000 nM
Beside the measured number, compound 4's estimate is 1.6-fold (0.20 log units) above it; the measured number falls inside the stated range.
By their numbers in this assay, from the lowest: compounds 2, 4, 1 and 3 (each within the scatter of the next).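

In this assay, removing the allyl group altogether gives only a small step (a 1.3-fold higher number from compound 2 to compound 4 (0.12 log units; within the scatter)), so a bare hydrogen on the aromatic nitrogen stands level with the allyl group. The earlier compounds shown here only exchanged one group for another at this position, whereas compound 4 shows that, in this series, the number does not depend on any group being present there. No supporting data are available to explain why the number stays flat across this change.

The compounds shown leave open whether an amine, a carboxylic acid or a longer chain on that nitrogen would shift the number beyond the scatter. They also leave open whether any group at this position can bring the number well below the level shared by all four compounds.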